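A methylsulfonyl swap among compounds held at a limit

The source may report more compounds than this note shows. Statements on the series, on what has been measured and on what is new or still open speak of the compounds shown alone.

In a physicochemical assay for solubility, using the shake flask method, in simulated intestinal fluid, measured as kinetic solubility, with a stated time of 2 h, at 25 degrees C, at pH 6.5 (a lower number here means a less soluble compound, a higher number a more soluble compound), compound 3 (`COc1ccccc1CN1C(=O)c2c(C)nc(-c3nc(C)no3)c(N)c2C1=O`) gives < 5000 nM as its reading, which is a limit and not a number. Compound 1 (`Cc1noc(-c2nc(C)c3c(c2N)C(=O)N(Cc2ccc(Cl)cc2)C3=O)n1`) gives < 5000 nM as its reading, also a limit. Compound 2 (`Cc1noc(-c2nc(C)c3c(c2N)C(=O)N(Cc2ccc(Br)cc2)C3=O)n1`) gives < 5000 nM as its reading, again a limit. Compound 3 therefore shares the limit of < 5000 nM in this assay, at which 3 of the 3 values shown sit, and has no measured place of its own among these compounds.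

Compound 4 (`Cc1noc(-c2nc(C)c3c(c2N)C(=O)N(Cc2ccc(S(C)(=O)=O)cc2)C3=O)n1`) carries 4-(methylsulfonyl)phenyl in place of 2-methoxyphenyl on a saturated chain carbon bound to an amide-type nitrogen in a ring. Two measured changes at that same place bear on it: a step that the two limits leave unreadable from compound 1 to compound 3 and a step that the two limits leave unreadable from compound 2 to compound 3. Less direct is a step that the two limits leave unreadable from compound 1 to compound 2 for bromo in place of chloro on an aromatic carbon. None of these steps has a readable size, so they give no measured guide to direction or magnitude. No change beyond the usual scatter is therefore expected, and the estimated step is a step that the limit leaves unreadable from compound 3 to compound 4 in this comparison. A further reading at the limit remains likely. The estimated value for compound 4 is 4000 nM within an expected range of 1500 nM to 12000 nM in this assay when it is measured.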

Compound 4, solubility: < 5000 nM
Compound 4: no number, only a limit (the forecaster's own chance of this, stated with the estimate: 65%); the middle value is on the limit's open side.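

In this assay compound 4 gives < 5000 nM, which is a limit and not a number. Its steps from compound 1, compound 2 and compound 3 therefore cannot be read, and all of them share one reading: the limit of < 5000 nM in this assay, at which 4 of the 4 values shown sit.

The compounds shown leave open what the actual solubility of any of the four is, and whether these changes of group move it at all.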